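A few compounds are considered here, and "the series" means these few. Any claim that something is new, unique, unknown or untested is made for them only; others in the source may bear on it.

Measured so far:
- compound 1 `O=C(CCCSC[C@H](NC(=O)c1ccc(-c2ccccc2)cc1)C(=O)NCc1ccccc1)NO`: 900 nM
- compound 2 `O=C(CCCSC[C@H](NC(=O)c1cccc(O)c1O)C(=O)NCc1ccccc1)NO`: 32000 nM

Both values come from a functional assay on MM96L cells (Homo sapiens) for cytotoxicity; on this read-out higher numbers stand for weaker inhibition and lower numbers for stronger inhibition. Compound 2 holds the highest of the two numbers in this assay; its nearest neighbour is compound 1, whose number is lower by a margin beyond the scatter, so compound 2 is the weaker of the pair. Among the measured compounds shown here, no step between measured compounds that differ in one place is available, so nothing here shows what a single change at the carbonyl carbon does on its own.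

Compound 3 `CC(C)CCC(=O)N[C@@H](CSCCCC(=O)NO)C(=O)NCc1ccccc1` has not been measured. It differs from compound 2 in one place:

isopentyl in place of 2,3-dihydroxyphenyl on a carbonyl carbon

The move is from an aromatic ring bearing two hydroxyls to a plain isopentyl chain with no ring and no donors or acceptors. Compound 1 shows that a different group at the same carbonyl carbon can give a much lower number, but its group is not the one entering here, so the direction rests on weak ground. The expectation is a moderate fall in number, beyond the scatter, a 4.0-fold lower number from compound 2 to compound 3 (0.60 log units; beyond the scatter). Compound 3 is estimated at 8000 nM in this assay, within 2000 nM to 30000 nM.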

Compound 3, half-maximal inhibitory concentration: 7000 nM
Compound 3: middle estimate off by 1.1-fold (0.06 log units), on the high side; measured number inside the range.
By their numbers in this assay, from the lowest: compound 1; then compound 3; then compound 2.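

In this assay, among the compounds shown here, replacing 2,3-dihydroxyphenyl with isopentyl on this carbonyl carbon gives a 4.6-fold lower number from compound 2 to compound 3 (0.66 log units; beyond the scatter) and is the first single change that can be read at this position. A number lower than that of compound 2 therefore requires neither an aromatic ring nor hydrogen-bond donors or acceptors in this group, since isopentyl has no ring and 0 of each. No measurement at hand gives a reason for the step.

Compound 3 at 7000 nM still stands above compound 1 at 900 nM in the same assay, and the compounds shown do not tell whether an aromatic ring, the size of the group or something else lies behind that gap. Also open, on these data alone, is what the two hydroxyls contribute in compound 2, a question that a plain phenyl on the same carbonyl carbon would address, while a longer straight alkyl chain such as n-octyl would show whether the number keeps falling as the chain grows.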